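The source may hold more compounds than are shown below. What is called first, only, known or untested is meant among the compounds shown, and "the series" means these compounds.

Measured compounds:
compound 1 `CC(=O)CCCCC(=O)N1CCN(c2nccc(Oc3cccc(C)c3)n2)CC1` — 0%
compound 2 `COC[C@@H]1CCCN1C(=O)C1CCCN1c1cc(Nc2cccc(Br)c2)ncn1` — 0%

In an assay on isolated protein for inhibition of calcium/calmodulin-dependent protein kinase type II subunit alpha (Homo sapiens), read by HTRF, tested at 10 uM (on this read-out lower numbers stand for less inhibition and higher numbers for more inhibition at the one concentration tested (going by the name of the read-out)), compound 1 gives 0%, and compound 2 gives 0%. The two values stand level at the digits shown, within the scatter of this assay, so neither can be called the stronger.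

Compound 3 `Cc1cccc(Oc2ccnc(N3CCN(C(=O)c4c(C)noc4C)CC3)n2)c1` has not yet been tested. It differs from compound 1 in one place: 3,5-dimethyl-1,2-oxazol-4-yl in place of 4-acetylbutyl on a carbonyl carbon. Within the data shown here, no measured pair shows what such a change does in this assay. With compound 1 at 0%, the step expected from compound 1 to compound 3 is a number 3 percentage points higher from compound 1 to compound 3 (within the scatter), none beyond the scatter. Compound 3 is therefore estimated at 3%, in a range from -7% to 14%.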

Compound 3, a percentage reported as inhibition, at one concentration (the size of the read-out at that concentration, not a potency): 0%
Compound 3: the middle estimate sits 3 percentage points above what was measured, within the range that was stated.
By their numbers in this assay, from the lowest: compounds 1, 2 and 3 (each within the scatter of the next).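

In this assay the swap of 4-acetylbutyl for 3,5-dimethyl-1,2-oxazol-4-yl on this carbonyl carbon gives no change at the digits printed from compound 1 to compound 3 (within the scatter) at this place. Compound 3 stands at 0% and so a five-membered aromatic ring here, like the open chain, brings no readable inhibition at the one concentration tested. No supporting evidence bears on this result.

From the compounds shown here alone, whether any group on this carbonyl carbon gives readable inhibition stays open, for instance a chain ending in an amine or a carboxylic acid. With all values level, the compounds shown cannot tell how much this position matters on the core of compound 1.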